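Tetrazole aryl swap: from thiophene to phenyl

The source may hold more compounds than are shown below. What is called first, only, known or untested is meant among the compounds shown, and "the series" means these compounds.

Measured so far in an assay for inhibition of Fatty-acid amide hydrolase 1 (Rattus norvegicus), at pH 9.0; on this read-out lower numbers stand for stronger inhibition and higher numbers for weaker inhibition:
compound 1 `O=C(CCCCCCc1ccccc1)c1ncc(-c2ccco2)s1`: 1500 nM
compound 2 `O=C(CCCCCCc1ccccc1)c1nnn(-c2ccco2)n1`: 5 nM
compound 3 `O=C(CCCCCCc1ccccc1)c1nnn(-c2cccs2)n1`: 8.5 nM

Compound 3 stands second highest of the three numbers in this assay; compound 2 is nearest, and compound 1 sits far above both. Compound 4 `O=C(CCCCCCc1ccccc1)c1nnn(-c2ccccc2)n1` differs from compound 3 by phenyl in place of thiophen-2-yl on an aromatic nitrogen. For the measured compounds named here, the one step that bears on it is a 1.7-fold higher number from compound 2 to compound 3 (0.23 log units; within the scatter), which shows that exchanging the five-membered group on the aromatic nitrogen moved the number little. The step to compound 4 is therefore expected to be small, at most a modest rise beyond compound 3, estimated as a 1.8-fold higher number from compound 3 to compound 4 (0.25 log units; within the scatter). Compound 4 is thus expected to give about 15 nM, within 5 nM to 45 nM.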

Compound 4, inhibition constant: 16 nM
The estimate for compound 4 lay 1.1-fold (0.03 log units) below the measured number; the range from low to high includes it.
By their numbers in this assay, from the lowest: compounds 2, 3 and 4 (each within the scatter of the next, the first and the last beyond it); then compound 1.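

In this assay, phenyl, a six-membered aromatic ring of carbon only, serves on the aromatic nitrogen about as well as thiophen-2-yl, with a 1.9-fold higher number from compound 3 to compound 4 (0.27 log units; within the scatter), so a ring hetero atom is not needed there for a number in this range. Against furan-2-yl, the same change gives a 3.2-fold higher number from compound 2 to compound 4 (0.51 log units; beyond the scatter), the first step at this position to pass the scatter, though only a modest one. No measured evidence accounts for either step.

The compounds shown leave open whether a phenyl carrying a methoxy group or a chlorine, or a pyridyl ring, would keep the number in this range on the same nitrogen. They also leave open how a shorter or longer chain would act on the shared core.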